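A few compounds are considered here, and "the series" means these few. Any claim that something is new, unique, unknown or untested is made for them only; others in the source may bear on it.

In a functional assay on NCI-H322 cells (Homo sapiens) for cytotoxicity, read by MTT assay, with a stated time of 24 h (on this read-out higher numbers stand for weaker inhibition and lower numbers for stronger inhibition), three compounds that share one core and differ only in the aryl group on an aromatic nitrogen have been measured. Compound 1 `COc1ccc(/C=C\C(=O)O)c(OCc2cn(-c3ccccc3I)nn2)c1CC=C(C)C` gives 42300 nM. Compound 2 `COc1ccc(/C=C\C(=O)O)c(OCc2cn(-c3ccc(CO)cc3)nn2)c1CC=C(C)C` gives 27100 nM, and compound 3 `COc1cccc(-n2cc(COc3c(/C=C\C(=O)O)ccc(OC)c3CC=C(C)C)nn2)c1` gives 25200 nM. Compound 3 has the lowest of the three numbers, yet the step of a 1.7-fold lower number from compound 1 to compound 3 (0.22 log units; within the scatter) and the step of a 1.1-fold lower number from compound 2 to compound 3 (0.03 log units; within the scatter) are both within the scatter, as is a 1.6-fold lower number from compound 1 to compound 2 (0.19 log units; within the scatter); so far the three aryl groups give numbers that cannot be told apart.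

Compound 4 `COc1ccc(/C=C\C(=O)O)c(OCc2cn(-c3cccnc3Cl)nn2)c1CC=C(C)C` keeps the core and changes the aryl group once more: 2-chloropyridin-3-yl in place of 3-methoxyphenyl on an aromatic nitrogen. All three measured steps bear on this change: each swaps one aryl group on the same aromatic nitrogen for another, and none of them moved the number beyond the scatter. A step of that kind is therefore expected again, with no change beyond the scatter in either direction, and compound 4 is expected to show a 1.1-fold higher number from compound 3 to compound 4 (0.05 log units; within the scatter). The estimate for compound 4 in this assay is 28000 nM, with a range from 14000 nM to 56000 nM.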

Compound 4, half-maximal inhibitory concentration: 42200 nM
The estimate for compound 4 lay 1.5-fold (0.18 log units) below the measured number, and the stated range covers the measured number.
By their numbers in this assay, from the lowest: compounds 3, 2, 4 and 1 (each within the scatter of the next).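

Going by these compounds alone, compound 4 brings the first aryl group in this set with a hetero atom in its six-membered aromatic ring, and in this assay this change still gives only small steps: a 1.7-fold higher number from compound 3 to compound 4 (0.22 log units; within the scatter) and a 1.6-fold higher number from compound 2 to compound 4 (0.19 log units; within the scatter) and a 1.0-fold lower number from compound 1 to compound 4 (0.00 log units; within the scatter) all stay within the scatter. The position on the aromatic nitrogen has now carried four different aryl groups, with iodo, hydroxymethyl, methoxy and chloro substituents and with either a carbon-only ring or a ring holding nitrogen, and their numbers cannot be told apart. No measured evidence is at hand to explain why these swaps leave the number within the scatter.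

From the compounds shown here alone, all four groups on this nitrogen are six-membered aromatic rings, so it remains open whether a plain alkyl chain there, or an aryl ring bearing an amine or a carboxylic acid, would move the number beyond the scatter in either direction. Going by these compounds, it is also open whether a change elsewhere on the shared core would do more than these aryl swaps have done.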